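The source may hold more compounds than are shown below. What is called first, only, known or untested is meant among the compounds shown, and "the series" means these compounds.

In a functional assay on KB cells (Homo sapiens) for cytotoxicity (on this read-out lower numbers stand for stronger inhibition and higher numbers for weaker inhibition), compound 1 (`CCOCn1cc(C#N)c2c(N)ncnc21`) gives > 100000 nM as a limit of the assay and not a number. Compound 2 (`C=CCn1cc(C#N)c2c(N)ncnc21`) gives > 100000 nM and this too is a limit. For the measured compounds named here, the series so far therefore stands at one mark (the limit of > 100000 nM in this assay, at which 2 of the 2 values shown sit) with no number for compound 2. Going by the values given here, the only measured step (a step that the two limits leave unreadable from compound 1 to compound 2) has no readable size and sets no direction. Compound 3 (`CCCn1cc(C#N)c2c(N)ncnc21`) differs from compound 2 by ethyl in place of vinyl on a saturated chain carbon bound to an aromatic nitrogen in a change that reads ethyl in place of vinyl on a saturated chain carbon bound to an aromatic nitrogen, or allyl to propyl when cut one bond further out. Among the compounds with values here, no step of readable size bears on this change, so no shift beyond the scatter is expected. The estimated step (a number no higher from compound 2 to compound 3 (the limit leaves the size open)) is accordingly small. Compound 3 is expected at 100000 nM with an estimated range from 40000 nM to 250000 nM and will probably be reported as a limit again.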

Compound 3, half-maximal inhibitory concentration: > 100000 nM
Compound 3: a limit, no number; the forecaster's own chance of this, stated with the estimate: 85%; the middle value lies on the limit itself.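

In this assay compound 3 gives > 100000 nM, a limit of the assay and not a number. The steps from compound 1 and from compound 2 to compound 3 cannot be read: the limit of > 100000 nM in this assay, at which 3 of the 3 values shown sit.

The compounds shown leave open whether any group at this chain carbon changes the read-out in this assay.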